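The source may hold more compounds than are shown below. What is called first, only, known or untested is meant among the compounds shown, and "the series" means these compounds.

Values so far in a functional assay, read by spectrophotometry, with a stated time of 6 min; a higher number here means that more compound is needed for the effect, a lower number that less compound is needed
- compound 1 `COc1c(C)cc(O)cc1C/C=C(\C)CC(=O)/C=C(/C)CCCC(C)C(=O)/C=C/C(C)(C)O` gives 26300 nM
- compound 2 `COc1c(C)cc(O)cc1C/C=C(\C)CC(=O)/C=C(\C)CCCC(C)C(=O)/C=C/C(C)(C)O` gives 24500 nM

Among the measured compounds shown here, compound 1 stands level with compound 2, its only measured neighbour, with a 1.1-fold lower number from compound 1 to compound 2 (0.03 log units; within the scatter). These two differ only in the drawn geometry of one double bond.

Compound 3 `COc1c(C)cc(O)cc1C/C=C(\C)CC(=O)/C=C(/C)CCCC(C)=O` has not yet been measured. Its difference from compound 1 is acetyl in place of 1-((3-hydroxy-3-methylbut-1-en-1-yl)carbonyl)ethyl on a saturated chain carbon, three bonds along the chain from a double-bonded chain carbon.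

For the measured compounds named here, the one measured step leaves that group untouched, so its size says nothing about this change. Going by the values given here, the only anchor is compound 1 at 26300 nM, and the data give no direction. In this assay no step beyond the scatter is therefore expected, though the range is kept wide to allow for a real one. The expected step is a 1.1-fold higher number from compound 1 to compound 3 (0.06 log units; within the scatter). For compound 3 the estimated value is 30000 nM, with an expected range from 8000 nM to 100000 nM.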

Compound 3, half-maximal effective concentration: 51600 nM
Compound 3: the middle estimate sits 1.7-fold (0.24 log units) below what was measured; measured number inside the range.
By their numbers in this assay, from the lowest: compounds 2, 1 and 3 (each within the scatter of the next, the first and the last beyond it).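

In this assay, acetyl in place of 1-((3-hydroxy-3-methylbut-1-en-1-yl)carbonyl)ethyl on a saturated chain carbon, three bonds along the chain from a double-bonded chain carbon, gives a 2.0-fold higher number from compound 1 to compound 3 (0.29 log units; within the scatter). Among the compounds shown here, this is the first reading at this position, and it shows that most of the group that leaves can be removed without a step beyond the scatter, although one pair cannot separate a small real effect from the spread of repeated measurements. Nothing available on these compounds bears on this step, so it carries no explanation.

As far as these compounds go, whether a carboxylic acid, an amine or a longer chain at this place would move the number beyond the scatter remains open, as does the effect of keeping only part of the group that leaves. Acetyl is shown with only one drawn geometry of the double bond, so whether that geometry matters in the shortened compound also remains open.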